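Second Methoxy Group on Compound 1: Expected Effect

The source may hold more compounds than are shown below. What is called first, only, known or untested is meant among the compounds shown, and "the series" means these compounds.

Compound 1 `COc1ccc(-c2cc(/C=C/C(=O)c3ccc(N)cc3)[nH]n2)cc1` was examined in a functional assay on DU-145 cells (Homo sapiens) for cytotoxicity, read by sulforhodamine B assay, with a stated time of 48 h, tested at 0.01 uM (a lower number here means a stronger effect, a higher number a weaker effect of the compound at the concentration tested), where compound 1 gives 104%. Compound 2 `COc1ccc(C(=O)/C=C/c2cc(-c3cc(OC)c(OC)c(OC)c3)n[nH]2)cc1` in this assay gives 102%. These two numbers lie within the usual scatter of each other, so compound 1 stands alongside compound 2, and neither shows a measurable effect at this concentration. Compound 3 `COc1ccc(-c2cc(/C=C/C(=O)c3ccc(N)cc3)[nH]n2)cc1OC` has not yet been measured in this assay. It differs from compound 1 by methoxy in place of hydrogen on an aromatic carbon. The step of a number 4 percentage points lower from compound 1 to compound 3 (within the scatter) is expected to be none beyond the scatter. Compound 3 is therefore estimated to give 100%, with a range from 88% to 112%.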

Compound 3, a percentage reported as activity, at one concentration (the size of the read-out at that concentration, not a potency): 109%
For compound 3 the middle estimate is 9 percentage points below the measured one; measured number inside the range.
By their numbers in this assay, from the lowest: compounds 2, 1 and 3 (each within the scatter of the next).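

In this assay, methoxy in place of hydrogen on an aromatic carbon, ortho to a methoxy group, gives a number 5 percentage points higher from compound 1 to compound 3 (within the scatter) and so adds no measurable effect at this concentration. Among the compounds shown here, this is the first direct reading at this position, since the two earlier compounds differ in more than one place. Nothing measured here explains the result.

From the compounds shown here alone, whether a hydroxy group, an amine or a longer chain at this position would behave differently remains open. So does whether this methoxy step would stay as small at a higher concentration, where the shared core might show an effect.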